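Methoxy to Vinyl on an Amidine Chain Against Arginase

This account rests on a few compounds, and the source may have more. Where it says the series, first, only, none or still open, it means among the compounds named here.

Measured compounds and their values in an assay for inhibition of arginase-1 (Bos taurus), with a stated time of 30 min, tested at 1 mM; on this read-out higher numbers stand for more inhibition at the one concentration tested (going by the name of the read-out) and lower numbers for less inhibition:

compound 1, `CCCCCNC(=N)NCCOC`, 15%
compound 2, `COCC(=N)NCCC[C@H](N)C(=O)O`, 22%
compound 3, `COCC(=N)NCCCCN`, 21%

All three compounds were tested at a single concentration, and their numbers lie within the usual scatter of one another. Compound 3 sits among them with no separation beyond that scatter: its value differs from that of compound 2 and from that of compound 1 by amounts that repeated measurements could produce on their own. Among the measured compounds shown here, the one step that can be read between two measured compounds, a number 1 percentage points lower from compound 2 to compound 3 (within the scatter), is itself within the scatter.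

Compound 4, `C=CCC(=N)NCCCCN`, is not yet measured. It differs from compound 3 in one place: vinyl in place of methoxy on a saturated chain carbon bound to a carbon with a double bond to nitrogen. For the measured compounds named here, no measured step touches this part of the molecule; the step from compound 2 to compound 3 concerns a different position, the chain carbon bound to the amine nitrogen, and it gave no change beyond the scatter. Going by the values given here, since nothing among the measured compounds bears on exchanging methoxy for vinyl, the expectation for compound 4 is a step of a number 1 percentage points lower from compound 3 to compound 4 (within the scatter) in this assay, that is, no shift beyond the scatter. Compound 4 is therefore estimated at 20%, with a range from 8% to 32%.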

Compound 4, a percentage reported as inhibition, at one concentration (the size of the read-out at that concentration, not a potency): 6%
Compound 4: middle estimate off by 14 percentage points, on the high side; the measured number lies below the stated range.
By their numbers in this assay, from the lowest: compounds 4, 1, 3 and 2 (each within the scatter of the next, the first and the last beyond it).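

In this assay, among the compounds shown here, vinyl in place of methoxy on a saturated chain carbon bound to a carbon with a double bond to nitrogen gives a number 15 percentage points lower from compound 3 to compound 4 (beyond the scatter) and is the first step here to pass beyond the scatter, whereas the earlier step, hydrogen in place of carboxy on a saturated chain carbon bound to an amine nitrogen and a saturated chain carbon, did not. So the read-out does respond to this change at this place, even though the inhibition seen throughout is small and comes from one concentration. Methoxy and vinyl hold the same number of heavy atoms, but methoxy brings an oxygen and a hydrogen-bond acceptor while vinyl brings a double bond, and no measurement here tells which of these differences lies behind the lower number.

As far as these compounds go, it remains open whether ethyl, which has neither the oxygen nor the double bond, would side with methoxy or with vinyl, and how a hydroxy group or an amine would fare at the same place. From the compounds shown here alone, it is also open whether vinyl would lower the number in the same way on the chain that keeps the carboxylic acid, as in compound 2.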